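Dithiocarbonate amides: extending the amide substituent chain

A few compounds are considered here, and "the series" means these few. Any claim that something is new, unique, unknown or untested is made for them only; others in the source may bear on it.

Measured so far in an assay on HEK293 cells for inhibition of protein deacetylase HDAC6 (Homo sapiens); a higher number here means a weaker inhibitor, a lower number a stronger inhibitor:
compound 1 `CCSC(=S)SCC(=O)c1ccc(C(=O)Nc2ccccc2)cc1` gives 521 nM
compound 2 `CCSC(=S)SCC(=O)c1ccc(C(=O)NCc2ccccc2)cc1` gives 830 nM
compound 3 `CCSC(=S)SCC(=O)c1ccc(NC(=O)c2cccnc2)cc1` gives 421 nM

All three compounds share the same core and differ in the amide part. Compound 2 sits within the usual scatter of both compound 1 and compound 3 in this assay; the three numbers cannot be separated from one another.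

Compound 4 `CCSC(=S)SCC(=O)c1ccc(C(=O)NCCOc2ccccc2)cc1` is not yet measured. It derives from compound 2 by phenoxymethyl in place of phenyl on a saturated chain carbon bound to an amide-type nitrogen; read one bond further out, the benzyl group becomes 2-phenoxyethyl. For the measured compounds named here, the only measured step that bears on this is the lengthening from compound 1 to compound 2: a 1.6-fold higher number from compound 1 to compound 2 (0.20 log units; within the scatter). That step, which inserted one chain carbon between the amide nitrogen and the phenyl ring, stayed within the scatter. Inserting a further two atoms, one of them an oxygen, is a change of the same kind but larger in extent, and no measured pair covers it directly. No step beyond the scatter is therefore expected, with the direction of the earlier step, if any, pointing toward a slightly higher number.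

The estimate for compound 4 in this assay is 1000 nM, with a range from 400 nM to 2500 nM; the step expected from compound 2 to compound 4 is a 1.2-fold higher number from compound 2 to compound 4 (0.08 log units; within the scatter).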

Compound 4, half-maximal inhibitory concentration: 483 nM
Compound 4: middle estimate off by 2.1-fold (0.32 log units), on the high side; the range from low to high includes it.
By their numbers in this assay, from the lowest: compounds 3, 4, 1 and 2 (each within the scatter of the next).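

In this assay the wider substituent on the amide-type nitrogen still gives no separable change: phenoxymethyl in place of phenyl on a saturated chain carbon bound to an amide-type nitrogen gives a 1.7-fold lower number from compound 2 to compound 4 (0.24 log units; within the scatter) and going from phenyl to 2-phenoxyethyl on this nitrogen gives a 1.1-fold lower number from compound 1 to compound 4 (0.03 log units; within the scatter) in this series. Where the earlier compounds covered only the change from phenyl to benzyl, phenyl, benzyl and 2-phenoxyethyl now all stand on this nitrogen with no step beyond the scatter, even with 8 heavy atoms and a hydrogen-bond acceptor entering in place of the 6 heavy atoms of phenyl. The numbers therefore show no trend with chain extension across compounds 1, 2 and 4, and no measurement is available that would account for this result.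

Still open, from the compounds shown here alone, is whether an amine or a carboxylic acid at the end of the chain, or a chain longer than 2-phenoxyethyl, would give a step beyond the scatter. The compounds shown also leave open whether any change to the shared core outside the amide part would separate from these numbers.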